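Hydroxamate cinnamides: exchanging chloro for isopropyl

The source may hold more compounds than are shown below. What is called first, only, known or untested is meant among the compounds shown, and "the series" means these compounds.

Going by the values given here, compound 2 `O=C(/C=C/c1ccc(/C=C/C(=O)c2ccc(Cl)cc2)o1)NO` holds the lowest of the two numbers measured so far: in a functional assay on HepG2 cells (Homo sapiens) for antiproliferative activity, read by MTT assay, with a stated time of 48 h (a higher number here means a weaker inhibitor, a lower number a stronger inhibitor), compound 2 gives 6740 nM. Compound 1 `O=C(/C=C/c1ccc(/C=C/C(=O)c2ccc3ccccc3c2)o1)NO` in this assay gives 9930 nM, which lies within the scatter of compound 2, so no order between the two can be claimed. Compound 3 `CC(C)c1ccc(C(=O)/C=C/c2ccc(/C=C/C(=O)NO)o2)cc1` is not yet measured; it differs from compound 2 by isopropyl in place of chloro on an aromatic carbon. Among the compounds with values here, no measured pair covers this change, so only a small step in this assay is expected, hardly beyond the scatter, if anything toward a weaker inhibitor. Compound 3 is estimated at 8000 nM, between 3000 nM and 20000 nM, an expected step of a 1.2-fold higher number from compound 2 to compound 3 (0.07 log units; within the scatter).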

Compound 3, half-maximal inhibitory concentration: 35900 nM
Beside the measured number, compound 3's estimate is 4.5-fold (0.65 log units) below it, and the stated range ends below it.
By their numbers in this assay, from the lowest: compounds 2 and 1 (each within the scatter of the next); then compound 3.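

In this assay, isopropyl in place of chloro on this aromatic carbon, para to a large group, gives a 5.3-fold higher number from compound 2 to compound 3 (0.73 log units; beyond the scatter). This is the first change in one place among these compounds, and it shows that the position is not indifferent to its substituent, with isopropyl giving the weaker inhibitor. Nothing available accounts for the step. On these data alone, one pair sets no trend, so it remains open whether a methyl, a methoxy or an amine on this carbon would stay near compound 2 or move toward compound 3.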